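The compounds below may be only part of what the source reports. "The series", "measured", "known", "first", "only" and "open" are said of these compounds alone.

Measured so far in the series:

Compound 1, `N#C[C@@H]1CCCN1C(=O)[C@@H]1C[C@H](CO)CN1`: 64%
Compound 2, `N#C[C@@H]1CCCN1C(=O)[C@@H]1C[C@H](C(=O)N2CCCCC2)CN1`: 84%

In an assay on the whole organism (plasma, strain Sprague-Dawley) for inhibition of Dipeptidyl peptidase 4 (Rattus norvegicus), with a stated time of 6 h, at a dose of 1 mg/kg by the oral route (a lower number here means less inhibition, a higher number more inhibition at the dose given (going by the name of the read-out)), compound 2 gives 84%, the higher of the two numbers recorded. Compound 1 gives 64% in this assay, and the gap between the two lies beyond the usual scatter of this read-out, so the inhibition of compound 2 in this assay is higher than that of compound 1 on the numbers shown. Going by the values given here, no step between measured compounds that differ in one place is available, so there is no measured single change to lean on.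

Compound 3, `CCN(C)C(=O)[C@@H]1CN[C@H](C(=O)N2CCC[C@H]2C#N)C1`, is the next compound for this assay. It differs from compound 2 in one place: ethyl(methyl)amino in place of piperidin-1-yl on a carbonyl carbon. Both groups are amide substituents without donors or acceptors, and the change is small in size. Among the compounds with values here, with only two measured compounds and no directly comparable step, the expected step from compound 2 is modest, most likely none beyond the scatter or a slight drop.

Compound 3 is expected to give 77% in this assay, with a range from 60% to 92%. The step this estimate implies, a number 7 percentage points lower from compound 2 to compound 3 (within the scatter), is expected to stay near the scatter.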

Compound 3, a percentage reported as inhibition, in the whole organism at one dose (the size of the read-out at that dose, not a potency): 71%
Compound 3: middle estimate off by 6 percentage points, on the high side; low and high end bracket the measured number.
By their numbers in this assay, from the lowest: compounds 1 and 3 (each within the scatter of the next); then compound 2.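

In this assay, going by these compounds alone, ethyl(methyl)amino in place of piperidin-1-yl on a carbonyl carbon gives a number 13 percentage points lower from compound 2 to compound 3 (beyond the scatter), the first measured single change at this place, and it shows that the read-out responds to the amide substituent even though neither group carries hydrogen-bond donors or acceptors. Ethyl(methyl)carbamoyl in place of hydroxymethyl on a saturated ring carbon gives a number 7 percentage points higher from compound 1 to compound 3 (within the scatter), so among the compounds shown, an amide at this place does not by itself set a compound apart from the hydroxymethyl compound, and the piperidin-1-yl amide of compound 2 is the one that reaches 84%. No measurement shown here bears on the cause of either step.

The compounds shown leave open whether the ring of piperidin-1-yl or only its larger atom count goes with the higher number, a question that pyrrolidin-1-yl, morpholine or dimethylamino on the same carbonyl carbon would help to settle. They also leave open how these steps would look in this assay if the amide carbonyl were replaced by an amine or a carboxylic acid at the same place.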